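Carbamate to Difluorobenzamide: Expected Vero Cell Cytotoxicity

This account rests on a few compounds, and the source may have more. Where it says the series, first, only, none or still open, it means among the compounds named here.

Measured compounds:
- compound 1 `COc1ccc(C(=O)Nc2cc3nc(C4CCCCC4)[nH]c3cc2N2CCCC2)cc1` gives > 100 ug/mL in an ADME assay on Vero cells (Chlorocebus sabaeus) for cytotoxicity, read by resazurin assay, with a stated time of 3 days; on this read-out higher numbers stand for weaker inhibition and lower numbers for stronger inhibition
- compound 2 `CN(C)c1cc2[nH]c(C3CCCCC3)nc2cc1NC(=O)OCc1ccccc1` gives > 100 ug/mL in this assay
- compound 3 `CCCN(CCC)c1cc2[nH]c(C3CCCCC3)nc2cc1NC(=O)OCc1ccccc1` gives > 100 ug/mL in this assay

Each of these three readings is a limit of the assay rather than a number, so none of the compounds has a measured value. Compound 2 therefore stands only at that limit, as do the two other compounds shown. Going by the values given here, the one comparison between measured compounds that differs in a single place, a step that the two limits leave unreadable from compound 2 to compound 3, is also unreadable for that reason; the only evidence is the limit of > 100 ug/mL in this assay, at which 3 of the 3 values shown sit.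

Compound 4 `CN(C)c1cc2[nH]c(C3CCCCC3)nc2cc1NC(=O)c1ccc(F)cc1F` differs from compound 2 by the change (2,4-difluorophenyl in place of benzyloxy on a carbonyl carbon). Among the compounds with values here, no measured step speaks to this change, and the steps that exist give no size at all. Within the data shown here, with every compound so far sitting at the same limit, the most that can be said is that compound 4 is expected to behave like compound 2.

Compound 4 is therefore estimated at 100 ug/mL, with a range from 50 ug/mL to 200 ug/mL. The estimated step is a number no higher from compound 2 to compound 4 (the limit leaves the size open), which is expected to be none beyond the scatter, with the result most likely reported again as a limit.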

Compound 4, half-maximal inhibitory concentration: > 100 ug/mL
Compound 4 gave a limit, no number; the forecaster's own chance of this, stated with the estimate: 80%; the middle value sits exactly at the limit.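

Going by these compounds alone, compound 2 and compound 4 both give a limit of the assay rather than a number, so no step between them can be read: the limit of > 100 ug/mL in this assay, at which 4 of the 4 values shown sit. The compounds shown leave open at what concentration, if any, each would reach half-maximal inhibition in this assay and which groups would shift that concentration.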